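Compound 4: a smaller ring on the sulfonyl sulfur

The source may hold more compounds than are shown below. What is called first, only, known or untested is meant among the compounds shown, and "the series" means these compounds.

Measured in a toxicity assay on HepG2 cells (Homo sapiens) for cytotoxicity, read by MTT assay, with a stated time of 48 h; on this read-out lower numbers stand for higher toxicity in this test and higher numbers for lower toxicity in this test:
Compound 1 `O=S(=O)(c1ccc(-c2ccc3nncc(Nc4ccc(OCc5ccccc5)c(Cl)c4)c3c2)cc1)N1CCOCC1`: > 15 uM
Compound 2 `CN1CCCN(S(=O)(=O)c2ccc(C3=CC4N=CN=C(Nc5ccc(OCc6cccc(F)c6)c(Cl)c5)C4S3)cc2)CC1`: > 15 uM
Compound 3 `CN1CCCN(S(=O)(=O)c2ccc(-c3ccc4ccnc(Nc5ccc(OCc6cccc(F)c6)c(Cl)c5)c4c3)cc2)CC1`: > 15 uM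

Compound 2 gives > 15 uM in this assay as a limit of the assay and not a number. The three measured compounds stand alike, with the limit of > 15 uM in this assay, at which 3 of the 3 values shown sit, as the whole of the evidence. Compound 4 `CN1CCN(S(=O)(=O)c2ccc(C3=CC4N=CN=C(Nc5ccc(OCc6cccc(F)c6)c(Cl)c5)C4S3)cc2)CC1` carries 4-methylpiperazin-1-yl in place of 4-methyl-1,4-diazepan-1-yl on a sulfonyl sulfur. Among the compounds with values here, no measured pair shows this change. The expectation therefore rests on compound 2 and its > 15 uM as a limit. The estimated step that the limit leaves unreadable from compound 2 to compound 4 is expected to stay within the scatter in this assay. Compound 4 is estimated at 20 uM, with an expected range from 10 uM to 40 uM.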

Compound 4, half-maximal toxic concentration: > 15 uM
Compound 4 gave a limit, no number (the forecaster's own chance of this, stated with the estimate: 80%); the middle value does not contradict the limit.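

Within the data shown here, compound 2 and compound 4 both sit at a limit of this assay, not at a number, and no step between them can be read. The compounds shown leave open whether changing this ring alters the read-out at all.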